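The compounds below may be only part of what the source reports. "The series", "measured", "known", "first", "only" and "open" are said of these compounds alone.

In a functional assay on SV5A8 cells (Homo sapiens) for cytotoxicity (a lower number here means a stronger inhibitor, a higher number a weaker inhibitor), compound 2 `Cc1ccc2c(NCc3ccc(NC(=O)C4CCN(Cc5ncc[nH]5)CC4)cc3)nc(N(C)C)nc2c1` gives only a limit, > 20000 nM. The other compound measured, compound 1 `Cc1ccc2c(NCc3ccc(NC(=O)C4CCN(Cc5ccccc5)CC4)cc3)nc(N3CCN[C@@H](C)C3)nc2c1`, likewise returns only a limit, > 8860 nM. Both results therefore sit at the edge of what the assay reports, as recorded in the limit of > 20000 nM in this assay, at which 1 of the 2 values shown sits, and (the limit of > 8860 nM in this assay, at which 1 of the 2 values shown sits). Compound 3 `Cc1ccc2c(NCc3ccc(NC(=O)C4CCN(Cc5ccco5)CC4)cc3)nc(N(C)C)nc2c1` differs from compound 2 by furan-2-yl in place of 1H-imidazol-2-yl on a saturated chain carbon bound to an amine nitrogen in a ring. Within the data shown here, with no measured step to draw on, no change beyond the usual scatter is expected for compound 3 in this assay. Compound 3 is estimated at 20000 nM, with a range from 8000 nM to 50000 nM. That estimate is expected to mean a step of a number no higher from compound 2 to compound 3 (the limit leaves the size open) in this assay.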

Compound 3, half-maximal inhibitory concentration: > 20000 nM
Compound 3: a limit, no number; the forecaster's own chance of this, stated with the estimate: 80%; the middle value sits exactly at the limit.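

In this assay, among these compounds, compound 2 and compound 3 both give only a limit, and no step between them can be read. The compounds shown leave open how furan-2-yl and 1H-imidazol-2-yl compare in this assay and what number any of the three compounds would give.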